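The source may hold more compounds than are shown below. What is called first, only, known or untested is meant among the compounds shown, and "the series" means these compounds.

Compound 1 `CCCCCCCCNC(=O)[C@@H](NC(=O)c1ccccc1)[C@@H](C)O` gives 136000 nM in a functional assay on HepG2 cells (Homo sapiens) for cytotoxicity, read by MTT assay, with a stated time of 48 h; a higher number here means a weaker inhibitor, a lower number a stronger inhibitor.
Compound 2 `CCCCCCCCNC(=O)[C@@H](NC(=O)c1ccco1)[C@@H](C)O` gives 192000 nM in this assay.
Compound 3 `CCCCCCCCCCCCNC(=O)[C@@H](NC(=O)c1ccccc1)[C@@H](C)O` gives > 400000 nM in this assay, which is a limit of the assay and not a number.

Compound 3 therefore stands at the top of the measured range, where the data only tell that its value sits at the limit of > 400000 nM in this assay, at which 1 of the 3 values shown sits. The step of an at least 2.9-fold higher number from compound 1 to compound 3 (0.46 log units; beyond the scatter) placed it there. Compound 4 `CCCCCCCCCCCCNC(=O)[C@@H](NC(=O)c1ccco1)[C@@H](C)O` differs from compound 3 by furan-2-yl in place of phenyl on a carbonyl carbon. The same change has already been measured once, as a 1.4-fold higher number from compound 1 to compound 2 (0.15 log units; within the scatter), a step within the scatter. The expectation for compound 4 is thus a step of no size beyond the scatter, most likely a value again reported only as a limit. Compound 4 is expected to give 500000 nM, within a range from 250000 nM to 1500000 nM. The expected step is a step that the limit leaves unreadable from compound 3 to compound 4.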

Compound 4, half-maximal inhibitory concentration: 147000 nM
The estimate for compound 4 lay 3.4-fold (0.53 log units) above the measured number; the measured number lies below the stated range.
By their numbers in this assay, from the lowest: compounds 1, 4 and 2 (each within the scatter of the next). At a limit, above all of these: compound 3.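

With the longer chain, furan-2-yl in place of phenyl on a carbonyl carbon gives an at least 2.7-fold lower number from compound 3 to compound 4 (0.43 log units; beyond the scatter), so the same change does not have the same effect on both cores: the same change on two cores in this assay, a 1.4-fold higher number (0.15 log units; within the scatter) from compound 1 to compound 2 and an at least 2.7-fold lower number (0.43 log units; beyond the scatter) from compound 3 to compound 4, at least 3.8-fold (0.58 log units) apart, beyond the scatter of two such steps. The added butyl also behaves differently with furan-2-yl, giving a 1.3-fold lower number from compound 2 to compound 4 (0.12 log units; within the scatter): the same change on two cores in this assay, an at least 2.9-fold higher number (0.46 log units; beyond the scatter) from compound 1 to compound 3 and a 1.3-fold lower number (0.12 log units; within the scatter) from compound 2 to compound 4, at least 3.8-fold (0.58 log units) apart, beyond the scatter of two such steps. Compound 3 gives > 400000 nM, which is a limit of the assay and not a number, so these gaps are minimum sizes.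

The compounds shown leave open whether a thiophene ring on that carbonyl carbon would behave like the furan-2-yl or the phenyl compounds. They also leave open what a still longer chain would do with each ring.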